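Methoxy for Fluoro on the Biaryl Urea

This account rests on a few compounds, and the source may have more. Where it says the series, first, only, none or still open, it means among the compounds named here.

Within the data shown here, compound 2 `Cc1ccc(CN2CCC(CCN(Cc3ccc(-c4ccc(F)cc4)cc3)C(=O)NC(C)C)CC2)cc1` is the one compound with a measured number in an in vitro functional assay on HEK293 cells for antagonist activity at melanin-concentrating hormone receptor 1 (Homo sapiens), read by GTPgammaS binding, with a stated time of 45 min; a higher number here means a more potent compound, by a factor of ten per unit of this negative logarithm, a lower number a less potent compound. Compound 1 `COc1ccc(-c2ccc(CN(CC(=O)C(C)(C)O)C(=O)NC3CCN(Cc4ccc(C)cc4)CC3)cc2)cc1` returns only a limit in this assay, namely < 5. In this assay compound 2 gives 6.42. Compound 3 `COc1ccc(-c2ccc(CN(CCC3CCN(Cc4ccc(C)cc4)CC3)C(=O)NC(C)C)cc2)cc1` keeps the core of compound 2 and carries the change (methoxy in place of fluoro on an aromatic carbon), methoxy in place of fluoro on an aromatic carbon. Among the measured compounds shown here, no measured pair shows this exchange, so the estimate treats it as a small change, with a number 0.02 log units lower from compound 2 to compound 3 (within the scatter) expected and no direction beyond the scatter. Compound 3 is therefore expected to reach 6.4 in this assay, between 5.7 and 7.1.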

Compound 3, negative logarithm of the antagonist equilibrium constant: 6.34
Compound 3: the middle estimate sits 0.06 log units above what was measured, within the range that was stated.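

In this assay, among these compounds, the exchange of 4-fluorophenyl for 4-methoxyphenyl gives a number 0.08 log units lower from compound 2 to compound 3 (within the scatter) and is the only measured pair at this position, para to a large group. This position thus takes methoxy, with its 2 heavy atoms and 1 hydrogen-bond acceptor, in place of fluoro without a step beyond the scatter. Nothing measured here bears on why the two groups read alike. Still open, on these data alone, is how this position responds to a group such as an amine or a carboxylic acid. Also open, as far as these compounds go, is whether the same exchange reads alike on another core.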